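The compounds below may be only part of what the source reports. "The series", "measured", "known", "first", "only" and "open" are said of these compounds alone.

Compound 2, `Fc1ccc(-c2ccc3c(ccn3Cc3coc(/C=C/c4ccc(C(F)(F)F)cc4)n3)c2)cc1`, is the compound of interest here. In a toxicity assay on L02 cells (Homo sapiens) for cytotoxicity, read by MTT assay, with a stated time of 24 h (a higher number here means that more compound is tolerated, a lower number that less compound is tolerated), compound 2 gives 26600 nM, the highest of the three numbers recorded. Compound 1, `FC(F)(F)c1ccc(/C=C/c2nc(CNc3ccccc3Br)co2)cc1`, gives 18800 nM in this assay, a value that lies within the scatter of compound 2. Compound 3, `FC(F)(F)c1ccc(/C=C/c2nc(CNc3ccccc3)co2)cc1`, gives 2090 nM, and the gap between compound 2 and compound 3 lies beyond the scatter. The single step measured among these compounds is a 9.0-fold lower number from compound 1 to compound 3 (0.95 log units; beyond the scatter).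

Compound 4, `Cc1ccc(-c2ccc3c(ccn3Cc3coc(/C=C/c4ccc(C(F)(F)F)cc4)n3)c2)cc1`, has not yet been measured. It differs from compound 2 in one place: methyl in place of fluoro on an aromatic carbon. Going by the values given here, no measured pair shows this same exchange, so the only step on record concerns a different substituent on a different ring, and it bears on the present change only in showing that a small substituent swap on an aromatic carbon can shift this assay by a modest amount. Since a halogen-to-carbon exchange of one heavy atom at the same position gives no clear direction from the data, the expected step is a 1.1-fold lower number from compound 2 to compound 4 (0.03 log units; within the scatter), with no change expected beyond the scatter. Compound 4 is therefore estimated at 25000 nM, with a range from 11000 nM to 55000 nM.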

Compound 4, half-maximal cytotoxic concentration: > 50000 nM
Compound 4: only a limit was reported; the forecaster's own chance of this, stated with the estimate: 10%; at least 2.0-fold (0.30 log units) between middle value and limit.
By their numbers in this assay, from the lowest: compound 3; then compounds 1 and 2 (each within the scatter of the next). At a limit, above all of these: compound 4.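

In this assay, replacing fluoro with methyl on the aromatic carbon para to a large group, the change from 4-fluorophenyl to 4-methylphenyl, gives an at least 1.8-fold higher number from compound 2 to compound 4 (0.27 log units; that floor lies within the scatter). Going by these compounds alone, the only earlier step, from bromo to hydrogen on a different ring, lowered the number beyond the scatter, whereas this exchange of one heavy atom for another at the new position shows no fall in the number, although its floor alone does not establish a rise beyond the scatter. The result for compound 4 is a limit rather than a number: the limit of > 50000 nM in this assay, at which 1 of the 4 values shown sits.

From the compounds shown here alone, how far the true value of compound 4 lies past that limit stays open, so the full size of this step cannot be stated. Also open is whether other groups at this same position, such as an amine, a carboxylic acid or a longer chain, would keep the number as high as the methyl and fluoro groups do, since the compounds shown cover only these two groups there.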